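A chain with selenium in place of chloro on the shared core

The compounds below may be only part of what the source reports. "The series", "measured", "known", "first", "only" and "open" are said of these compounds alone.

Compound 2 `COc1ccc(N(C)c2ccnc(Cl)n2)cc1Cl` gives the highest of the three numbers in a functional assay on HeLa cells (Homo sapiens) for antiproliferative activity, read by MTT assay, with a stated time of 48 h (on this read-out lower numbers stand for stronger inhibition and higher numbers for weaker inhibition), at 517 nM. Compound 1 `COc1ccc(N(C)c2ccnc(Cl)n2)cc1F` gives 241 nM, and compound 3 `COc1ccc(N(C)c2ccnc(Cl)n2)cc1OCCCCBr` gives 307 nM. Taken as steps, the first change is a 2.1-fold higher number from compound 1 to compound 2 (0.33 log units; beyond the scatter), modest and beyond the scatter, while the second is a 1.7-fold lower number from compound 2 to compound 3 (0.23 log units; within the scatter), which stays within it.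

Compound 4 `COc1ccc(N(C)c2ccnc(Cl)n2)cc1OCC[Se]C#N` is yet to be measured in this assay. It differs from compound 2 in one place: a group of 6 heavy atoms (3 carbon, 1 nitrogen, 1 oxygen, 1 selenium; no ring) in place of one chlorine atom, on an aromatic carbon. The step that bears most directly on this is a 1.7-fold lower number from compound 2 to compound 3 (0.23 log units; within the scatter), where a chain of several heavy atoms also replaced the chlorine atom at the same aromatic carbon and the number moved only within the scatter. The step of a 2.1-fold higher number from compound 1 to compound 2 (0.33 log units; beyond the scatter) shows that the chlorine atom itself sits at the weaker end of the three measured compounds, so trading it for a chain is not expected to raise the number. On this basis compound 4 is expected to land close to compound 3, with a step of a 1.6-fold lower number from compound 2 to compound 4 (0.21 log units; within the scatter) that lies at the edge of the scatter. The estimate for compound 4 is 320 nM, within a range from 150 nM to 680 nM.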

Compound 4, half-maximal inhibitory concentration: 436 nM
Compound 4: middle estimate off by 1.4-fold (0.13 log units), on the low side, within the range that was stated.
By their numbers in this assay, from the lowest: compounds 1, 3, 4 and 2 (each within the scatter of the next, the first and the last beyond it).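

Compound 4 shows that the aromatic carbon ortho to a methoxy group accepts a chain holding selenium and a nitrile much as it accepts 4-bromobutoxy. In this assay, replacing the chlorine atom with this group of 6 heavy atoms stays within the scatter (a 1.2-fold lower number from compound 2 to compound 4 (0.07 log units; within the scatter)), and exchanging the end of the chain against compound 3 also stays within it (a 1.4-fold higher number from compound 3 to compound 4 (0.15 log units; within the scatter)), so selenium at this place cannot be told apart from the bromine-bearing chain on this read-out. The step from the fluoro compound is also within the scatter (a 1.8-fold higher number from compound 1 to compound 4 (0.26 log units; within the scatter)), so compound 4 cannot be separated from either compound 1 or compound 2, although those two lie beyond the scatter of each other. Nothing shown here gives a reason for these numbers.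

The compounds shown leave open whether a longer chain carrying the same selenium end would stay in this narrow band. They also leave open whether a chain ending in an amine or a carboxylic acid at this aromatic carbon would move the number beyond the scatter.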